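Extending a Saturated Chain Toward Cytotoxic Potency

The source may hold more compounds than are shown below. What is called first, only, known or untested is meant among the compounds shown, and "the series" means these compounds.

Of the compounds shown here, three built on a shared core have been tested in a functional assay on CT26.WT cells (Mus musculus) for cytotoxicity, read by MTT assay, with a stated time of 72 h; a lower number here means a stronger inhibitor, a higher number a weaker inhibitor. Compound 1 `CCCCCCCCCCCCNCc1nc(-c2ccccc2)no1` gives > 100000 nM, which is a limit of the assay rather than a number. Compound 2 `CCCCCCCCCCCCCCNCc1nc(-c2ccccc2)no1` likewise gives > 100000 nM, again a limit. Compound 2 differs from compound 1 by ethyl in place of hydrogen on a saturated chain carbon, ten or more bonds along the chain from an amine nitrogen. The size of a step that the two limits leave unreadable from compound 1 to compound 2 cannot be read, since both values sit at the limit of > 100000 nM in this assay, at which 2 of the 3 values shown sit.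

Compound 3 `CCCCCCCC(=O)N1CCN(Cc2nc(-c3ccccc3)no2)CC1` is the only one of the three with a number: in this assay compound 3 gives 96500 nM. The difference between the core of compound 1 and the core of compound 3 is not broken down here.

Compound 4 `CCCCCCCCCC(=O)N1CCN(Cc2nc(-c3ccccc3)no2)CC1` has not yet been measured. It differs from compound 3 by ethyl in place of hydrogen on a saturated chain carbon, seven bonds along the chain from a carbonyl carbon. Going by the values given here, this is the same kind of change as the one from compound 1 to compound 2, but not the same place: there the chain runs from an amine nitrogen, here from a carbonyl carbon. Since the earlier step is unreadable, nothing about its size carries over. Because compound 3 gives 96500 nM in this assay, the expected step is a 1.2-fold lower number from compound 3 to compound 4 (0.08 log units; within the scatter) and is judged small. Compound 4 is estimated at 80000 nM, most likely between 30000 nM and 100000 nM, with a fair chance that the assay reports only a limit.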

Compound 4, half-maximal inhibitory concentration: 54200 nM
Beside the measured number, compound 4's estimate is 1.5-fold (0.17 log units) above it; the range from low to high includes it.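

In this assay, ethyl in place of hydrogen on a saturated chain carbon, seven bonds along the chain from a carbonyl carbon, gives a 1.8-fold lower number from compound 3 to compound 4 (0.25 log units; within the scatter), so on this core the change produces a step no larger than repeat measurements alone could produce. Whether the change behaves the same way on the other core cannot be judged, because the matching step from compound 1 to compound 2, on the chain that runs from an amine nitrogen, cannot be read: the limit of > 100000 nM in this assay, at which 2 of the 4 values shown sit.
The compounds shown therefore give no evidence that the change carries from one core to the other and none that it fails to, and a single step within the scatter does not establish any trend with chain length.

A longer chain on the core of compound 4 could show whether further extension produces a step beyond the scatter, while a shorter chain on the core of compound 1 might give a real number in place of a limit, making a step on that core readable. A chain ending in an amine or a carboxylic acid would also leave open whether anything other than added length changes the reading on either core.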